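The source may hold more compounds than are shown below. What is called first, only, known or untested is meant among the compounds shown, and "the series" means these compounds.

Measured so far:

Compound 1 `CC(=O)c1cccc(-c2ccc(C(=O)N(Cc3cccc(OCCCCCC(=O)O)c3)C(C)C)cc2)c1`: in an ADME assay on BJ cells (Homo sapiens) for cytotoxicity, read by CellTiter-Glo and resazurin assay, with a stated time of 72 h (on this read-out higher numbers stand for an effect only at larger amounts of compound and lower numbers for an effect already at smaller amounts), compound 1 gives only a limit of the assay, > 26000 nM.
Compound 2 `COc1cccc(-c2ccc(C(=O)N(Cc3cccc(OCCCCCC(=O)O)c3)C(C)C)cc2)c1`: in this assay compound 2 gives only a limit of the assay, > 20900 nM.
Compound 3 `CC(C)N(Cc1cccc(OCCCCCC(=O)O)c1)C(=O)c1ccc(-c2cccc(C(F)(F)F)c2)cc1`: in this assay compound 3 gives only a limit of the assay, > 26000 nM.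

Compound 3 thus stands nowhere that can be ranked: its value is a limit, and the two further values shown are limits as well, two of them sitting at the limit of > 26000 nM in this assay, at which 2 of the 3 values shown sit, and one at the limit of > 20900 nM in this assay, at which 1 of the 3 values shown sits. Within the data shown here, no compound in this set can be called more or less toxic than another.

The next compound, compound 4 `CC(C)N(Cc1cccc(OCCCCCC(=O)O)c1)C(=O)c1ccc(-c2cccc([N+](=O)[O-])c2)cc1`, differs from compound 3 by one change: nitro in place of trifluoromethyl on an aromatic carbon. The measured steps that touch the same aromatic carbon are a step that the two limits leave unreadable from compound 1 to compound 3 and a step that the two limits leave unreadable from compound 2 to compound 3, with a step that the two limits leave unreadable from compound 1 to compound 2 as the third edge of that triangle; none of them has a readable size, so no direction or magnitude can be carried over to the step to compound 4.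

With every neighbour at a limit, compound 4 is expected to give 30000 nM in this assay, with a range from 10000 nM to 100000 nM, most probably again reported as a limit. The step from compound 3 to compound 4 is accordingly estimated as a step that the limit leaves unreadable from compound 3 to compound 4, nothing beyond the scatter.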

Compound 4, half-maximal effective concentration: > 26000 nM
Compound 4: only a limit was reported; the forecaster's own chance of this, stated with the estimate: 85%; the middle value does not contradict the limit.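

In this assay compound 4 gives only a limit, as do compound 1, compound 2 and compound 3, and the steps from each of these three to compound 4 cannot be read. The compounds shown leave open whether acetyl, methoxy, trifluoromethyl or nitro on this aromatic carbon makes any difference, and at what concentration any of them would reach a half-maximal effect.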